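The source may report more compounds than this note shows. Statements on the series, on what has been measured and on what is new or still open speak of the compounds shown alone.

Within the data shown here, in a functional assay on DU-145 cells (Homo sapiens) for antiproliferative activity, read by WST assay, with a stated time of 48 h, tested at 1 uM (on this read-out lower numbers stand for a weaker effect and higher numbers for a stronger effect at the one concentration tested), compound 2 `Cc1ccc2[nH]c(-n3[nH]c(C)c(C)c3=O)nc2c1` gives -11% and stands lowest of the two numbers measured so far, the nearest being compound 1 `Cc1ccc2[nH]c(-n3[nH]c(C)c(Cc4ccccc4)c3=O)nc2c1` with 35%. Among the measured compounds shown here, the one measured step that bears on the next change is a number 46 percentage points lower from compound 1 to compound 2 (beyond the scatter). Compound 3 `Cc1ccc2[nH]c(-n3[nH]c(C)c(Cc4ccc(Cl)cc4)c3=O)nc2c1` differs from compound 2 by 4-chlorophenyl in place of hydrogen on a saturated chain carbon bound to an aromatic carbon, which returns an aromatic ring to the same place, now carrying a chlorine. On the strength of that single step, a rise beyond the scatter is expected, estimated as a number 46 percentage points higher from compound 2 to compound 3 (beyond the scatter). Compound 3 is therefore expected to reach 35%, with a range from 15% to 55%.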

Compound 3, a percentage reported as inhibition, at one concentration (the size of the read-out at that concentration, not a potency): -1%
The estimate for compound 3 lay 36 percentage points above the measured number; measured number outside the range, below it.
By their numbers in this assay, from the lowest: compounds 2 and 3 (each within the scatter of the next); then compound 1.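

In this assay, a number 10 percentage points higher from compound 2 to compound 3 (within the scatter), so 4-chlorophenyl on this saturated chain carbon does not reproduce what phenyl gives there. The aromatic ring alone is therefore not sufficient at this position, and the chloro group on the aromatic carbon matters, with a number 36 percentage points lower from compound 1 to compound 3 (beyond the scatter). No available evidence explains this sensitivity to one chloro group.

As far as these compounds go, whether the effect of compound 1 survives any other group at that ring carbon, such as fluoro or methoxy, stays open. So does whether a longer chain between the ring and the core keeps it.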